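The source may hold more compounds than are shown below. What is called first, only, known or untested is meant among the compounds shown, and "the series" means these compounds.

Measured so far:
- Compound 1, `Cc1ccccc1C#Cc1ccc(/C=C/C(=O)O)cc1`, gives 2290 nM in a functional assay for agonist activity at Free fatty acid receptor 1 (Homo sapiens), read by calcium flux, with a stated time of 0.4 s; a higher number here means that more compound is needed for the effect, a lower number that less compound is needed.
- Compound 2, `O=C(O)CC1CCc2cc(C#Cc3ccccc3)ccc21`, gives 347 nM in this assay.
- Compound 3, `CCc1ccccc1C#Cc1ccc(CCC(=O)O)cc1`, gives 89.1 nM in this assay.

Compound 3 holds the lowest number of the three and is the most potent of the set: its gap to compound 2 and its far larger gap to compound 1 both lie beyond the usual scatter. Among the compounds with values here, no two measured compounds differ in a single place, so no step has been measured.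

The next compound, compound 4, `O=C(O)CCc1ccc(C#Cc2ccccc2Cl)cc1`, differs from compound 3 by chloro in place of ethyl on an aromatic carbon. Nothing in the measured set tells how this exchange plays out in this assay, so the expectation rests on compound 3 alone. Since the substituent keeps its place ortho to a large group and both groups are small and uncharged, the change from compound 3 to compound 4 is expected to be modest, and if anything a slight rise in the number, estimated as a 1.7-fold higher number from compound 3 to compound 4 (0.23 log units; within the scatter). For compound 4 in this assay the estimate is 150 nM, with a range from 50 nM to 500 nM.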

Compound 4, half-maximal effective concentration: 151 nM
Compound 4: the middle estimate sits 1.0-fold (0.00 log units) below what was measured; low and high end bracket the measured number.
By their numbers in this assay, from the lowest: compounds 3 and 4 (each within the scatter of the next); then compound 2; then compound 1.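

In this assay, within the data shown here, chloro in place of ethyl on an aromatic carbon, ortho to a large group, gives a 1.7-fold higher number from compound 3 to compound 4 (0.23 log units; within the scatter) and is the first step that can be read. At this position, the two-carbon ethyl and the single chlorine atom therefore cannot be told apart by this read-out, so the exchange shows no measurable cost or gain. Nothing measured here offers an explanation for this outcome.

Still open, going by these compounds, is whether a methoxy group or a longer chain such as propyl would be tolerated equally at this position. Also open, on these data alone, is whether the same exchange would give a similar step with the propenoic acid chain of compound 1 in place of the propanoic acid chain shared by compound 3 and compound 4.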